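The source may hold more compounds than are shown below. What is called first, only, known or untested is meant among the compounds shown, and "the series" means these compounds.

Compound 1 `Cc1cc(C)c(S(=O)(=O)NC2=NCCN2C(=S)SN2CCn3c2nsc3=S)c(C)c1`: in a functional assay on KYSE-510 cells (Homo sapiens) for antiproliferative activity, read by crystal violet staining, with a stated time of 96 h (a higher number here means a weaker inhibitor of growth, a lower number a stronger inhibitor of growth), compound 1 gives >= 20000 nM, a limit of the assay.
Compound 2 `CC(=O)Nc1ccc(S(=O)(=O)NC2=NCCN2C(=S)SN2CCn3c2nsc3=S)cc1`: in this assay compound 2 gives >= 20000 nM, likewise a limit of the assay.

Compound 2 therefore stands only at the limit of >= 20000 nM in this assay, at which 2 of the 2 values shown sit, and carries no number of its own. Among the measured compounds shown here, the single measured step, a step that the two limits leave unreadable from compound 1 to compound 2, exchanged the aryl group on the sulfonyl sulfur and left both ends at that limit, so its size cannot be read.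

Compound 3 `O=[N+]([O-])c1ccc(S(=O)(=O)NC2=NCCN2C(=S)SN2CCn3c2nsc3=S)cc1` keeps the shared core of compound 2 and differs from it by nitro in place of acetamido on an aromatic carbon. For the measured compounds named here, the only step that bears on it is the unreadable one from compound 1 to compound 2 on the same aryl ring; it gives neither a size nor a direction, and nothing here supports a step beyond the scatter in this assay. Compound 3 is expected to give 25000 nM (range 8000 nM to 60000 nM) in this assay, most probably again reported as a limit. The step that the limit leaves unreadable from compound 2 to compound 3 is estimated to stay within the scatter.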

Compound 3, concentration for 50% growth inhibition: >= 20000 nM
Compound 3: a limit, no number; the forecaster's own chance of this, stated with the estimate: 80%; the middle value lies beyond the limit too.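

Compound 3 sits at the same assay limit as compound 1 and compound 2, so no step among these three compounds can be read: the limit of >= 20000 nM in this assay, at which 3 of the 3 values shown sit.

The compounds shown leave open whether any aryl group on the sulfonyl sulfur of the shared core gives a numerical value in this assay.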